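Moving the Fluorine on the Arylamine of Compound 3

This account rests on a few compounds, and the source may have more. Where it says the series, first, only, none or still open, it means among the compounds named here.

Compound 3 `C=CC(=O)Nc1cccc(NC(=O)CSc2nc(Nc3ccccc3F)c3ccccc3n2)c1` gives 26100 nM in a functional assay on MGC-803 cells (Homo sapiens) for inhibition, read by MTT assay, with a stated time of 72 h (on this read-out lower numbers stand for stronger inhibition and higher numbers for weaker inhibition), the highest of the two numbers measured, with compound 1 `O=C(CSc1nc(Nc2ccccc2)c2ccccc2n1)Nc1ccc(Br)cc1` nearest to it at 19300 nM; the gap between the two lies within the scatter, so neither can be called weaker or stronger. Compound 2 `CCc1ccc(NC(=O)CSc2nc(Nc3ccccc3)c3ccccc3n2)cc1` reaches only the limit of > 50000 nM in this assay, a limit rather than a number, as described by the limit of > 50000 nM in this assay, at which 1 of the 3 values shown sits. Within the data shown here, the one measured step, an at least 2.5-fold higher number from compound 1 to compound 2 (0.41 log units; beyond the scatter), concerns the group on the anilide ring and is a different change from the one now considered.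

Compound 4 `C=CC(=O)Nc1cccc(NC(=O)CSc2nc(Nc3ccc(F)cc3)c3ccccc3n2)c1` differs from compound 3 only in 4-fluorophenyl in place of 2-fluorophenyl on a nitrogen on an aromatic ring. Among the measured compounds shown here, no measured pair speaks to this change: the fluorine keeps the same ring and only changes its place on it, and the anilide part is untouched. With nothing in the measured steps pointing in either direction, compound 4 is expected to stay close to compound 3, with a step of a 1.0-fold lower number from compound 3 to compound 4 (0.00 log units; within the scatter), not beyond the scatter. Compound 4 is therefore estimated at 26000 nM in this assay, within a range from 10000 nM to 60000 nM.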

Compound 4, half-maximal inhibitory concentration: 8290 nM
Estimate against measurement, compound 4: 3.1-fold (0.50 log units) above, outside the stated range (below it).
By their numbers in this assay, from the lowest: compound 4; then compounds 1 and 3 (each within the scatter of the next). At a limit, above all of these: compound 2.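

The place of the fluorine on the phenyl group matters in this assay: with the same atoms and an untouched anilide part, 4-fluorophenyl in place of 2-fluorophenyl on a nitrogen on an aromatic ring gives a 3.1-fold lower number from compound 3 to compound 4 (0.50 log units; beyond the scatter) for this pair. Among these compounds, the only earlier step concerned the group on the anilide ring, so this is the first measured sign that the arylamine side of the series also moves the number, and that a change of position alone, with no atom gained or lost, can take a compound beyond the scatter. Nothing measured among these compounds bears on why the position of the fluorine shifts the number.

Going by these compounds, it remains open whether 3-fluorophenyl, 4-chlorophenyl or 4-methoxyphenyl on the same nitrogen would follow compound 4 or compound 3, and whether 4-fluorophenyl would have a similar effect with the bromo or ethyl anilide of the other compounds. Also open, on these data alone, is what a plain acetyl or propanoyl group would do in place of the acryloyl group that compound 3 and compound 4 share.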